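This account rests on a few compounds, and the source may have more. Where it says the series, first, only, none or still open, it means among the compounds named here.

Measured in an ADME assay on L6 cells (Rattus norvegicus) for cytotoxicity; a higher number here means a weaker inhibitor, a lower number a stronger inhibitor:
compound 1, `CN(C)C12CC(O)C(C(c3ccccc3)C1)C(c1ccccc1)C2`: 133000 nM
compound 2, `OC1CC2(N3CCCC3)CC(c3ccccc3)C1C(c1ccccc1)C2`: 26800 nM
compound 3, `COc1ccc(C2CC3(N(C)C)CC(O)C2C(c2ccc(OC)cc2)C3)cc1`: 63400 nM

Compound 2 differs from compound 1 by the change (pyrrolidin-1-yl in place of dimethylamino on a saturated ring carbon); in this assay this gives a 5.0-fold lower number from compound 1 to compound 2 (0.70 log units; beyond the scatter). Compound 4, `COc1ccc(C2CC3(N4CCCC4)CC(O)C2C(c2ccc(OC)cc2)C3)cc1`, not yet measured, relates to compound 3 by pyrrolidin-1-yl in place of dimethylamino on a saturated ring carbon. The difference between the cores of compound 1 and compound 3 is not broken down here. The two changes are the same kind of change but not the same: around the place the ring atom that bears a phenyl group in compound 1 bears a 4-methoxyphenyl group in compound 3. Among the measured compounds shown here, the step expected from compound 3 to compound 4 in this assay is a 4.9-fold lower number from compound 3 to compound 4 (0.69 log units; beyond the scatter), resting on the one earlier step of a 5.0-fold lower number from compound 1 to compound 2 (0.70 log units; beyond the scatter). For compound 4 the estimate in this assay is 13000 nM, between 5000 nM and 35000 nM.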

Compound 4, half-maximal inhibitory concentration: 17900 nM
The estimate for compound 4 lay 1.4-fold (0.14 log units) below the measured number, within the range that was stated.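

In this assay pyrrolidin-1-yl in place of dimethylamino also lowers the number on the core bearing 4-methoxyphenyl groups, giving a 3.5-fold lower number from compound 3 to compound 4 (0.55 log units; beyond the scatter) as its step. The change therefore carries over between these two cores in direction and in size, but two pairs show nothing about cores with other groups on the ring atoms, nor about any other assay. The two steps do not differ beyond the scatter: the same change on two cores in this assay, a 5.0-fold lower number (0.70 log units; beyond the scatter) from compound 1 to compound 2 and a 3.5-fold lower number (0.55 log units; beyond the scatter) from compound 3 to compound 4, 1.4-fold (0.15 log units) apart, within the scatter of two such steps.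

Other amines at the same ring carbon, such as piperidin-1-yl or morpholin-4-yl, remain open. So does the step on a core with a 4-chlorophenyl group in place of the 4-methoxyphenyl group.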